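Moving Atoms Within the Head Group of an Inactive Series

The source may hold more compounds than are shown below. What is called first, only, known or untested is meant among the compounds shown, and "the series" means these compounds.

Three compounds of the same terpenoid family were tested in a functional assay on T47D cells (Homo sapiens) for antiproliferative activity, read by sulforhodamine B assay, with a stated time of 48 h; on this read-out lower numbers stand for stronger inhibition and higher numbers for weaker inhibition. Compound 1 `CC(=O)O[C@H](C/C=C(\C)CC/C=C(\C)CCC1=C(C)CCC(=O)C1(C)C)C1=CC(=O)OC1` gives only a limit of the assay, > 10000 nM. Compound 2 `CC1=C(CC/C(C)=C/CC/C(C)=C/C[C@@H](O)C2=CC(=O)OC2)C(C)(C)CCC1` likewise gives only a limit, > 10000 nM. Compound 3 `CC1=C(CC/C(C)=C/CC/C(C)=C/CCC2=CC(=O)OC2O)C(C)(C)CCC1=O` also gives only a limit, > 10000 nM. So compound 2 stands nowhere in particular on these numbers: it sits at the limit of > 10000 nM in this assay, at which 3 of the 3 values shown sit, together with the two other compounds, and no compound gives a number at all.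

Compound 4 `CC1=C(CC/C(C)=C/CC/C(C)=C/CCC2=CC(=O)OC2O)C(C)(C)CCC1` has the same atoms as compound 2 but joined differently, which the change a group of 8 heavy atoms (5 carbon, 3 oxygen; one five-membered non-aromatic ring with 1 hetero atom) in place of a group of 8 heavy atoms (5 carbon, 3 oxygen; one five-membered non-aromatic ring with 1 hetero atom), on a saturated chain carbon bound to a double-bonded chain carbon describes. Among the measured compounds shown here, no measured pair of compounds differs in just one place, so no measured step can be leaned on. The expected step that the limit leaves unreadable from compound 2 to compound 4 is none beyond the scatter. This expectation rests on compound 3, which carries the same entering group on a core differing only by a ketone and gives only a limit, > 10000 nM. Compound 4 is therefore expected to give 20000 nM, within a range from 8000 nM to 60000 nM, most likely reported as a limit again.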

Compound 4, half-maximal inhibitory concentration: 5100 nM
Compound 4: the middle estimate sits 3.9-fold (0.59 log units) above what was measured; the measured number lies below the stated range.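

Joining the same atoms differently in the head group, on a saturated chain carbon bound to a double-bonded chain carbon, gives the first true number of this series in this assay, and the change comes to an at least 1.9-fold lower number from compound 2 to compound 4 (0.29 log units; that floor lies within the scatter). This place can therefore respond to how the head group is joined, but a real gain is not proven, as the comparison rests on a value that is only a limit: the limit of > 10000 nM in this assay, at which 3 of the 4 values shown sit. With the same entering group and a ketone added to the core, compound 3 gives > 10000 nM, a limit of the assay.

As far as these compounds go, the true value of compound 2 remains open, and with it the real size of the step. Also open, from the compounds shown here alone, is whether an amine in place of the hydroxyl on the ring would keep the activity of compound 4.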